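Trimming the isobutyl tail of a sulfonamide series

The source may report more compounds than this note shows. Statements on the series, on what has been measured and on what is new or still open speak of the compounds shown alone.

In a functional assay on M21 cells (Homo sapiens) for antiproliferative activity, read by sulforhodamine B assay, with a stated time of 48 h (on this read-out higher numbers stand for weaker inhibition and lower numbers for stronger inhibition), the measured compounds stand as follows:
Compound 1 `O=C1NCCN1c1ccc(S(=O)(=O)Nc2cccc(Br)c2)cc1` gives 59 nM.
Compound 2 `CC(C)Cc1ccc(NS(=O)(=O)c2ccc(N3CCNC3=O)cc2)cc1` reaches only a limit of this assay, > 1000 nM.
Compound 3 `O=C1NCCN1c1ccc(S(=O)(=O)Nc2ccc(Br)cc2)cc1` gives 130 nM.

Compound 2 thus sits at the edge of what this assay reports, with no number of its own (the limit of > 1000 nM in this assay, at which 1 of the 3 values shown sits). The measured steps are a 2.2-fold higher number from compound 1 to compound 3 (0.34 log units; beyond the scatter) and an at least 7.6-fold lower number from compound 2 to compound 3 (0.88 log units; beyond the scatter). Compound 4 `Cc1ccc(NS(=O)(=O)c2ccc(N3CCNC3=O)cc2)cc1` differs from compound 2 by hydrogen in place of isopropyl on a saturated chain carbon bound to an aromatic carbon. Going by the values given here, only the step with bromo in place of isobutyl bears on this change, and it was large; a methyl is a smaller change than a bromo, so a lower number is expected, by a smaller margin. Compound 4 is therefore estimated at 450 nM, between 150 nM and 1500 nM, an expected step of an at least 2.2-fold lower number from compound 2 to compound 4 (0.34 log units; beyond the scatter).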

Compound 4, half-maximal inhibitory concentration: 260 nM
Compound 4: middle estimate off by 1.7-fold (0.24 log units), on the high side; measured number inside the range.
By their numbers in this assay, from the lowest: compound 1; then compounds 3 and 4 (each within the scatter of the next). At a limit, above all of these: compound 2.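

Cutting isobutyl back to methyl gives an at least 3.8-fold lower number from compound 2 to compound 4 (0.58 log units; beyond the scatter) in this assay, so the longer tail is not needed at this place. Compound 2 has only a limit, which makes that step a minimum: the limit of > 1000 nM in this assay, at which 1 of the 4 values shown sits. Methyl reads level with bromo, a 2.0-fold higher number from compound 3 to compound 4 (0.30 log units; within the scatter) being no real gap, while the 3-bromophenyl group keeps its lead, with a 4.4-fold higher number from compound 1 to compound 4 (0.64 log units; beyond the scatter) as the measure of it.

Still open, going by these compounds, is where the number starts to climb along the chain, at ethyl or at propyl. Also open, on these data alone, is how an amine or a carboxylic acid would read in the same place.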